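A few compounds are considered here, and "the series" means these few. Any claim that something is new, unique, unknown or untested is made for them only; others in the source may bear on it.

Compound 1 `CCOCc1[nH]c(=O)c(-c2nnc(Cc3ccc(Cl)cc3)o2)c(O)c1-c1c(OC)cccc1OC`: 94%
Compound 2 `COCCc1[nH]c(=O)c(-c2nnc(Cc3ccc(Cl)cc3)o2)c(O)c1-c1c(OC)cccc1OC`: 86%

In an ADME assay on microsomes from liver (Homo sapiens) for metabolic stability, read by mass spectrometry, using NADPH, with a stated time of 10 min (on this read-out lower numbers stand for a less stable compound and higher numbers for a more stable compound), compound 2 gives 86%, which stands within the scatter of compound 1. Compound 3 `CCCCc1[nH]c(=O)c(-c2nnc(Cc3ccc(Cl)cc3)o2)c(O)c1-c1c(OC)cccc1OC` follows from compound 2 by ethyl in place of methoxy on a saturated chain carbon, two bonds along the chain from an aromatic carbon, with ethyl in place of methoxy on a saturated chain carbon, two bonds along the chain from an aromatic carbon. Among the measured compounds shown here, only one measured step bears on this, a number 8 percentage points lower from compound 1 to compound 2 (within the scatter). For the measured compounds named here, it also alters the chain, but no measured compound carries butyl, so the guidance is indirect. The expected change is a number 1 percentage points lower from compound 2 to compound 3 (within the scatter), so no step beyond the scatter is expected. For compound 3 the estimated value is 85%, within an expected range of 70% to 97%.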

Compound 3, percent of the compound remaining in the Homo sapiens assay: 66%
Beside the measured number, compound 3's estimate is 19 percentage points above it; the measured number lies below the stated range.
By their numbers in the Homo sapiens assay, from the lowest: compound 3; then compounds 2 and 1 (each within the scatter of the next).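

In the Homo sapiens assay this chain position turns out not to be indifferent: with ethyl in place of methoxy there is a number 20 percentage points lower from compound 2 to compound 3 (beyond the scatter), and the comparison with the ethoxy chain gives a number 28 percentage points lower from compound 1 to compound 3 (beyond the scatter), whereas the earlier pair showed only a number 8 percentage points lower from compound 1 to compound 2 (within the scatter). In a physicochemical assay for solubility, in phosphate buffer, with a stated time of 24 h, at pH 7.4 (a higher number here means a more soluble compound, a lower number a less soluble compound), the same change also lowers solubility: the measured solubility of compound 2, 73 ug/mL, and of compound 3, < 1 ug/mL, an at least 73-fold lower number (1.86 log units; beyond the scatter) In the physicochemical assay compound 2 gives 73 ug/mL as its measured solubility. In the physicochemical assay compound 3 gives < 1 ug/mL as its number, and this is a limit of the assay: the limit of < 1 ug/mL in the physicochemical assay, at which 1 of the 2 values shown sits.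

The compounds shown leave open whether the loss follows from the missing chain oxygen or from the butyl chain as such. They also leave open whether an amine or a carboxylic acid at the end of the chain would hold up in both read-outs.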